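A smaller group on the carbonyl of compound 3

The source may hold more compounds than are shown below. What is called first, only, known or untested is meant among the compounds shown, and "the series" means these compounds.

In an ADME assay on MDBK cells (Bos taurus) for cytotoxicity, read by MTT assay, with a stated time of 96 h (on this read-out higher numbers stand for lower toxicity in this test and lower numbers for higher toxicity in this test), the measured compounds stand as follows:
Compound 1 `FC(F)(F)c1cccc(NC(=S)Nc2ccc(Cl)cc2)c1` gives 17000 nM
Compound 2 `FC(F)(F)c1cccc(NC(=S)Nc2ccccc2)c1` gives 49000 nM
Compound 3 `O=C(NC(=S)Nc1cccc(C(F)(F)F)c1)[C@H]1C[C@@H]2CC[C@H]1C2` gives 10000 nM

Compound 3 at 10000 nM lies within the usual scatter of compound 1 and, beyond that scatter, under compound 2 on the numbers of this assay. Compound 4 `CC(=O)NC(=S)Nc1cccc(C(F)(F)F)c1` keeps the rest of compound 3 and differs in one place: one carbon atom in place of a group of 7 heavy atoms (7 carbon; 2 five-membered non-aromatic rings of carbon only), on a carbonyl carbon. A methyl thus takes the place of the group with 2 five-membered non-aromatic rings of carbon only, on a carbonyl carbon.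

Going by the values given here, no measured step covers this change. The only one available, a 2.9-fold higher number from compound 1 to compound 2 (0.46 log units; beyond the scatter), replaces chloro with hydrogen on an aromatic carbon, in another part of the structure. It was modest, though beyond the scatter, and it serves here mainly as a gauge of size. In that single step the number rose as the substituent became smaller, which gives a tentative direction but no pattern. A modest rise is therefore expected, and no change beyond the scatter remains possible. The expected move is a 2.5-fold higher number from compound 3 to compound 4 (0.40 log units; beyond the scatter) in the estimate made here. Compound 4 is estimated at 25000 nM, with an expected range from 10000 nM to 70000 nM.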

Compound 4, half-maximal cytotoxic concentration: > 100000 nM
Compound 4: only a limit was reported; the forecaster's own chance of this, stated with the estimate: 15%; middle value at least 4.0-fold (0.60 log units) away from the limit.
By their numbers in this assay, from the lowest: compounds 3 and 1 (each within the scatter of the next); then compound 2. At a limit, above all of these: compound 4.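

In this assay compound 4 gives > 100000 nM, which is a limit of the assay and not a number, and it is the only such value among the compounds shown: the limit of > 100000 nM in this assay, at which 1 of the 4 values shown sits.

Going by these compounds alone, the carbonyl carbon had no measured step until now, and the change of the group with 2 five-membered non-aromatic rings of carbon only to methyl gives an at least 10-fold higher number from compound 3 to compound 4 (1.00 log units; beyond the scatter), so this position clearly moves the number, and by more than the one earlier step did. Acetyl in place of 4-chlorophenyl on an amide-type nitrogen gives an at least 5.8-fold higher number from compound 1 to compound 4 (0.76 log units; beyond the scatter), while acetyl in place of phenyl gives an at least 2.0-fold higher number from compound 2 to compound 4 (0.30 log units; that floor lies within the scatter), so only the first of these two steps separates its compounds, and all three steps are floors whose full size stays unknown.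

The compounds shown leave open whether the number climbs gradually or abruptly between the two groups on the carbonyl carbon, a gap that an ethyl, a cyclopentyl or a phenyl there would help to fill. They also leave open whether an amine or a longer chain at this place would hold the number at the limit.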